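Isoxazoline indoles: methoxy to fluoro on the fused ring

The source may report more compounds than this note shows. Statements on the series, on what has been measured and on what is new or still open speak of the compounds shown alone.

Measured compounds:
- compound 1 `COc1cc(C2=NOC(c3c[nH]c4ccccc34)C2)cc(OC)c1OC` gives 15500 nM in a functional assay on PC-3 cells (Homo sapiens) for inhibition, read by MTT assay, with a stated time of 48 h; on this read-out higher numbers stand for weaker inhibition and lower numbers for stronger inhibition
- compound 2 `COc1ccc2c(C3CC(c4ccncc4)=NO3)c[nH]c2c1` gives 10500 nM in this assay
- compound 3 `COc1ccc2c(C3CC(c4ccncc4)=NO3)cn(Cc3ccc(Cl)cc3)c2c1` gives 95100 nM in this assay

Compound 2 gives the lowest number of the three. Compound 1 sits within the scatter of it, so no order between compound 1 and compound 2 can be claimed. The one step that is shown, a 9.1-fold higher number from compound 2 to compound 3 (0.96 log units; beyond the scatter), concerns the aromatic nitrogen, not the carbon ring, and so does not bear on the change considered here.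

Compound 4 `Fc1ccc2c(C3CC(c4ccncc4)=NO3)c[nH]c2c1` differs from compound 2 by fluoro in place of methoxy on an aromatic carbon. Within the data shown here, no measured pair in this set tests an exchange on that carbon, so the data give no basis for a step in either direction. The expectation is therefore a step no larger than the scatter, a 1.1-fold higher number from compound 2 to compound 4 (0.06 log units; within the scatter), and compound 4 is estimated at 12000 nM, with a range from 4000 nM to 40000 nM.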

Compound 4, half-maximal inhibitory concentration: 12900 nM
Estimate against measurement, compound 4: 1.1-fold (0.03 log units) below; the measured number falls inside the stated range.
By their numbers in this assay, from the lowest: compounds 2, 4 and 1 (each within the scatter of the next); then compound 3.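

Notes on the carbon position: in this assay, fluoro in place of methoxy gives a 1.2-fold higher number from compound 2 to compound 4 (0.09 log units; within the scatter), so this first direct reading at this position does not separate the two compounds. In this pair, the methoxy group and its hydrogen-bond acceptor are not needed for a number in this range, since fluoro, which has no such acceptor, reads alike. No measurement shown here offers an explanation for this result.

From the compounds shown here alone, whether an amine, a carboxylic acid or a longer alkoxy chain on this aromatic carbon would move the number beyond the scatter remains open. Also open, going by these compounds, is whether fluoro and methoxy would still read alike with the 4-chlorobenzyl group of compound 3 on the aromatic nitrogen.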